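The source may hold more compounds than are shown below. What is called first, only, known or untested is meant among the compounds shown, and "the series" means these compounds.

Three sulfonamide-linked amines have been measured in a functional assay on MIA PaCa-2 cells (Homo sapiens) for inhibition, read by MTT assay, with a stated time of 72 h; a lower number here means a stronger inhibitor of growth, a higher number a weaker inhibitor of growth. Compound 1 `COc1cccc(CNCCCNS(=O)(=O)c2cc(C(F)(F)F)cc(C(F)(F)F)c2)c1` gives 3400 nM, compound 2 `O=S(=O)(NCCCCCCNCc1ccc(Br)cc1)c1ccc2ccsc2c1` gives 6000 nM, and compound 3 `CC(C)(C)c1ccc(S(=O)(=O)NCCCCCCNCc2ccc(Br)cc2)cc1` gives 2970 nM. Compound 1 stands second highest of these three numbers, but its gaps to compound 3 and to compound 2 both lie within the usual scatter, so the three cannot be ranked against each other. Compound 4 `COc1ccccc1CNCCCNS(=O)(=O)c1cc(C(F)(F)F)cc(C(F)(F)F)c1` holds the same atoms as compound 1, joined differently: 2-methoxyphenyl in place of 3-methoxyphenyl on a saturated chain carbon bound to an amine nitrogen. Within the data shown here, no measured pair here differs in only one place, so nothing shows what such an exchange does. Without a step to rest on, the estimated change in this assay is none beyond the scatter, no change at the digits printed from compound 1 to compound 4 (within the scatter). Compound 4 is therefore expected to give about 3400 nM, within 1500 nM to 7500 nM.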

Compound 4, concentration for 50% growth inhibition: 3100 nM
Estimate against measurement, compound 4: 1.1-fold (0.04 log units) above, and the stated range covers the measured number.
By their numbers in this assay, from the lowest: compounds 3, 4, 1 and 2 (each within the scatter of the next, the first and the last beyond it).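

In this assay, 2-methoxyphenyl in place of 3-methoxyphenyl on a saturated chain carbon bound to an amine nitrogen gives a 1.1-fold lower number from compound 1 to compound 4 (0.04 log units; within the scatter) and so stays within the scatter. This is the first pair shown that differs in one place, and at this place the two methoxyphenyl groups cannot be told apart in this measurement. No measurement at hand offers an explanation for this result. From the compounds shown here alone, what a chlorine or a carboxylic acid in place of the methoxy would do remains open. So does the effect of a longer chain in compound 1.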